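A few compounds are considered here, and "the series" means these few. Any claim that something is new, unique, unknown or untested is made for them only; others in the source may bear on it.

Measured so far in an ADME assay on HCT-116 cells (Homo sapiens) for cytotoxicity, read by CellTiter-Glo, with a stated time of 72 h; a higher number here means a weaker inhibitor, a lower number a stronger inhibitor:

- compound 1 `Cc1cc(C)c(S(=O)(=O)N2CCC(N3CCC(CCO)CC3)CC2)c(C)c1`: > 5000 nM, a limit of the assay
- compound 2 `CC1CCN(C2CCN(S(=O)(=O)c3cnc(Cl)s3)CC2)CC1`: > 10000 nM, a limit of the assay
- compound 3 `CC1CCN(C2CCN(S(=O)(=O)c3ccc(Cl)nc3)CC2)CC1`: > 10000 nM, a limit of the assay

In this assay compound 1 stands only at a limit, > 5000 nM, and no number is known for it. Compound 2 likewise sits at a limit, > 10000 nM. Compound 3 also sits at a limit, > 10000 nM. Going by the values given here, the one single-point step, a step that the two limits leave unreadable from compound 2 to compound 3, is therefore unreadable, and nothing more can be taken from it than the limit of > 10000 nM in this assay, at which 2 of the 3 values shown sit, and the limit of > 5000 nM in this assay, at which 1 of the 3 values shown sits: every value so far is a limit.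

Compound 4 `Cc1cc(C)c(S(=O)(=O)N2CCC(N3CCCCC3)CC2)c(C)c1` differs from compound 1 by hydrogen in place of 2-hydroxyethyl on a saturated ring carbon. Among the compounds with values here, no measured step touches this change; the step from compound 2 to compound 3 concerns another part of the core. Within the data shown here, the only guide is that compound 1, compound 2 and compound 3 all remain at a limit. The step that the limit leaves unreadable from compound 1 to compound 4 is therefore expected to be none beyond the scatter, with compound 4 most likely again reported only as a limit. For compound 4 the estimate is 8000 nM, within 3000 nM to 30000 nM.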

Compound 4, half-maximal inhibitory concentration: > 5000 nM
Compound 4: a limit, no number; the forecaster's own chance of this, stated with the estimate: 80%; the middle value is on the limit's open side.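

No step can be read between compound 1 and compound 4 in this assay because both compounds stand only at a limit of the assay: the limit of > 5000 nM in this assay, at which 2 of the 4 values shown sit. The compounds shown leave open whether hydrogen in place of 2-hydroxyethyl changes the half-maximal inhibitory concentration at all.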